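Dropping the aryl substituents of compound 1

The source may report more compounds than this note shows. Statements on the series, on what has been measured and on what is new or still open speak of the compounds shown alone.

Measured compounds:
compound 1 `COc1ccc(/C=C2\S/C(=N\c3ccc(C)c(Cl)c3)N(C)C2=O)cc1` at 14100 nM
compound 2 `FC(F)(F)c1cc(/N=C2/NC/C(=C/c3ccccc3)S2)cc(C(F)(F)F)c1` at 16100 nM
compound 3 `COc1ccc(/C=C2/CN(C)/C(=N/c3ccc(Br)cc3)S2)cc1` at 8900 nM

All three values come from a functional assay on HCT-116 cells (Homo sapiens) for antiproliferative activity, read by MTT assay, with a stated time of 72 h; a lower number here means a stronger inhibitor, a higher number a weaker inhibitor. Compound 1 lies within the scatter of both compound 2 and compound 3, so the three cannot be ranked. For the measured compounds named here, no pair among them differs in one place only, which leaves the next change without a measured precedent. Compound 4 `COc1ccc(/C=C2\S/C(=N\c3ccccc3)N(C)C2=O)cc1` keeps the core of compound 1 and carries phenyl in place of 3-chloro-4-methylphenyl on a double-bonded nitrogen. A small shift toward a higher number is expected, possibly none beyond the scatter, and the estimated step runs a 1.3-fold higher number from compound 1 to compound 4 (0.11 log units; within the scatter). Compound 4 is expected at about 18000 nM, with an estimated range of 8000 nM to 40000 nM.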

Compound 4, half-maximal inhibitory concentration: > 100000 nM
Compound 4: no number, only a limit; the forecaster's own chance of this, stated with the estimate: 15%; middle value at least 5.5-fold (0.74 log units) from the limit.
By their numbers in this assay, from the lowest: compounds 3, 1 and 2 (each within the scatter of the next). At a limit, above all of these: compound 4.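

Phenyl in place of 3-chloro-4-methylphenyl on a double-bonded nitrogen gives an at least 7.0-fold higher number from compound 1 to compound 4 (0.85 log units; beyond the scatter) in this assay on the shared core. For the compounds shown here, this is the only one-place comparison so far, and it shows that this position does not tolerate loss of the aryl substituents as the other compounds might have suggested. Compound 4 has no number, only a limit of the assay: the limit of > 100000 nM in this assay, at which 1 of the 4 values shown sits.

Whether the chlorine or the methyl accounts for the step stays open: neither is seen alone on the phenyl. Also open, from the compounds shown here alone, is whether an amine or a carboxylic acid on that phenyl would give a measurable value.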